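A few compounds are considered here, and "the series" means these few. Any claim that something is new, unique, unknown or untested is made for them only; others in the source may bear on it.

Measured so far in an assay on isolated protein for inhibition of lysosomal alpha-glucosidase (Homo sapiens), tested at 1000 uM; a lower number here means less inhibition, a higher number more inhibition at the concentration tested (going by the name of the read-out):

Compound 1, `Cc1ccc([C@]2(CO)NC[C@@H](O)[C@@H]2O)cc1`: 21.3%
Compound 2, `COc1ccc([C@]2(CO)NC[C@@H](O)[C@@H]2O)cc1`: 40.2%
Compound 3, `OC[C@@]1(c2cccc(F)c2)NC[C@@H](O)[C@@H]1O`: 10.3%

Compound 3 stands lowest of the three numbers in this assay. Its nearest neighbour is compound 1, whose number is higher by an amount beyond the scatter, and its furthest is compound 2, higher still. The step followed here leads from compound 3 to compound 4, `OC[C@@]1(c2ccccc2)NC[C@@H](O)[C@@H]1O`, and consists of hydrogen in place of fluoro on an aromatic carbon. Only one measured step exists among these compounds, a number 18.9 percentage points higher from compound 1 to compound 2 (beyond the scatter). That step concerns an exchange of methoxy for methyl, not the removal of a fluoro, so it bears on the present change only indirectly: it shows that a single substituent on the ring can shift the number in this assay by a modest amount. Nothing measured tells whether the loss of fluoro moves the number up or down. The expectation is therefore a step of about a number 4.7 percentage points higher from compound 3 to compound 4 (within the scatter), not beyond the scatter. Compound 4 is estimated at 15%, with a range from 4% to 30%.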

Compound 4, a percentage reported as inhibition, at one concentration (the size of the read-out at that concentration, not a potency): 35%
Compound 4: the middle estimate sits 20 percentage points below what was measured; measured number above the stated range.
By their numbers in this assay, from the lowest: compound 3; then compound 1; then compounds 4 and 2 (each within the scatter of the next).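

In this assay, hydrogen in place of fluoro gives a number 24.7 percentage points higher from compound 3 to compound 4 (beyond the scatter), so fluoro on this aromatic carbon, meta to a group of 9 heavy atoms, goes with less inhibition than the unsubstituted ring. Hydrogen in place of methyl gives a number 13.7 percentage points higher from compound 1 to compound 4 (beyond the scatter), while hydrogen in place of methoxy gives a number 5.2 percentage points lower from compound 2 to compound 4 (within the scatter), so among these compounds fluoro and methyl both fall short of the unsubstituted ring, and methoxy cannot be told apart from it. Nothing measured here offers a reason for these steps.

The compounds shown leave open how an amine, a hydroxyl or a carboxylic acid on this aromatic carbon would read in this assay. They also leave open whether chloro, a close relative of fluoro, would give a similarly low number.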